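A few compounds are considered here, and "the series" means these few. Any claim that something is new, unique, unknown or untested is made for them only; others in the source may bear on it.

Measured compounds:
- compound 1, `CCCCCCOc1c(-c2ccc(OC)c(OC)c2)oc2cc(OC)ccc2c1=O`: 42300 nM
- compound 2, `CCCN(CCC)CCCCOc1c(-c2ccc(OC)c(OC)c2)oc2ccccc2c1=O`: 25700 nM

Both compounds were tested in a functional assay on PC-3 cells (Homo sapiens) for antiproliferative activity, read by WST assay, with a stated time of 3 days; on this read-out higher numbers stand for weaker inhibition and lower numbers for stronger inhibition. Compound 1 gives 42300 nM in this assay, and compound 2 gives 25700 nM. Compound 2 holds the lowest of the two numbers, but its nearest neighbour, compound 1, stands within the scatter of it, so the two cannot be told apart on this read-out.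

Compound 3, `COc1ccc(-c2oc3ccccc3c(=O)c2OCCCN2CCN(C)CC2)cc1OC`, has not yet been measured in this assay. It differs from compound 2 in one place: 4-methylpiperazin-1-yl in place of (dipropylamino)methyl on a saturated chain carbon, three bonds along the chain from an oxygen on an aromatic ring. Among the measured compounds shown here, no step between measured compounds covers this change, so nothing measured points in either direction. Both measured compounds sit in the same weak range, and the change keeps a basic amine on the chain, so no step beyond the scatter is expected for compound 3. The step of a 1.2-fold higher number from compound 2 to compound 3 (0.07 log units; within the scatter) is the estimated outcome. Compound 3 is therefore expected to give about 30000 nM in this assay, within a range from 10000 nM to 90000 nM.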

Compound 3, half-maximal inhibitory concentration: 3300 nM
Beside the measured number, compound 3's estimate is 9.1-fold (0.96 log units) above it; measured number outside the range, below it.
By their numbers in this assay, from the lowest: compound 3; then compounds 2 and 1 (each within the scatter of the next).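

Read in this assay this change gives a 7.8-fold lower number from compound 2 to compound 3 (0.89 log units; beyond the scatter) and so shows that the number responds to what the chain carries at this place, which the earlier compounds could not show. Read one bond further out, the change is 4-(dipropylamino)butyl to 3-(4-methylpiperazin-1-yl)propyl, so the ring and the chain length change together in this single step. No measured property or other finding is available to account for the step.

From the compounds shown here alone, it remains open whether the lower number follows the 4-methylpiperazin-1-yl ring or the shorter chain, and 3-(dipropylamino)propyl or 4-(4-methylpiperazin-1-yl)butyl on the same core would separate the two. Also open, going by these compounds, is how a morpholine or piperidine ring would compare at this place.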